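Ester to acid on the benzyl group: a limit-to-limit step

This account rests on a few compounds, and the source may have more. Where it says the series, first, only, none or still open, it means among the compounds named here.

In an assay on isolated protein for activation of cGMP-dependent protein kinase 1 (Homo sapiens), read by ADP-Glo, with stated times of 30 min and 2 h (on this read-out lower numbers stand for an effect already at smaller amounts and higher numbers for an effect only at larger amounts of compound), compound 1 `COC(=O)c1ccc(CN2CCC[C@H](O[C@H](CO)c3cc(Cl)cc(Cl)c3)[C@@H]2c2ccccc2)c(C)c1` reaches only the limit of the assay, > 200000 nM. Compound 3 `Cc1cc(C(=O)O)ccc1CN1CCC[C@H](O[C@H](CO)c2cc(F)cc(F)c2)[C@@H]1c1ccccc1` also stops at the limit, > 200000 nM. For compound 2 `Cc1cc(C(=O)O)ccc1CN1CCC[C@H](O[C@H](CO)c2cc(Cl)cc(Cl)c2)[C@@H]1c1cccc(F)c1` this assay holds no number, "nd" (no result reported). Across the numbers shown, compound 1 therefore stands nowhere above the others: it shares the limit at which the measured values sit (the limit of > 200000 nM in this assay, at which 2 of the 3 values shown sit). Compound 4 `O=C(O)c1ccc(CN2CCC[C@H](O[C@H](CO)c3cc(Cl)cc(Cl)c3)[C@@H]2c2ccccc2)cc1` differs from compound 1 by a group of 9 heavy atoms (7 carbon, 2 oxygen; one six-membered aromatic ring of carbon only) in place of a group of 11 heavy atoms (9 carbon, 2 oxygen; one six-membered aromatic ring of carbon only), on a saturated chain carbon bound to an amine nitrogen in a ring. Going by the values given here, no measured step connects the two, and no shift beyond the scatter is expected a number no higher from compound 1 to compound 4 (the limit leaves the size open). Compound 4 is expected to come out at about 200000 nM, estimated between 50000 nM and 600000 nM, most likely again as a limit.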

Compound 4, half-maximal effective concentration: 77000 nM
Beside the measured number, compound 4's estimate is 2.6-fold (0.41 log units) above it; low and high end bracket the measured number.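

In this assay, going by these compounds alone, the 4-carboxyphenyl group on the saturated chain carbon bound to an amine nitrogen in a ring gives the only value that is not a limit, with an at least 2.5-fold lower number from compound 1 to compound 4 (0.41 log units; beyond the scatter). This place therefore responds to a change of group, although the whole group changes in one step. The true size of the step stays open, because the value for compound 1 is a limit: the limit of > 200000 nM in this assay, at which 2 of the 4 values shown sit.

On these data alone, it remains open whether the carboxylic acid alone or the missing ring methyl carries the step. As far as these compounds go, how a primary amide or a tetrazole would read at this place is also open.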